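This account rests on a few compounds, and the source may have more. Where it says the series, first, only, none or still open, it means among the compounds named here.

Compound 1 `O=C(c1ccncc1)N1N=C(c2cc3ccccc3o2)CC1c1ccccc1O` and compound 2 `O=C(c1ccncc1)N1N=C(c2cc3ccccc3o2)CC1c1ccc(Cl)cc1` are the two compounds measured in an ADME assay on Vero cells (Chlorocebus sabaeus) for cytotoxicity, read by MTT assay, with a stated time of 72 h; a higher number here means a weaker inhibitor, a lower number a stronger inhibitor. In this assay compound 1 gives > 195000 nM, which is a limit of the assay and not a number. In this assay compound 2 gives > 220000 nM, likewise a limit. The step that the two limits leave unreadable from compound 1 to compound 2 cannot be read, since the limit of > 195000 nM in this assay, at which 1 of the 2 values shown sits, and the limit of > 220000 nM in this assay, at which 1 of the 2 values shown sits, both stand at limits, so compound 1 stands only at a limit, with no number of its own.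

Compound 3 `COc1ccc(C2CC(c3cc4ccccc4o3)=NN2C(=O)c2ccncc2)cc1` differs from compound 1 by 4-methoxyphenyl in place of 2-hydroxyphenyl on a saturated ring carbon. Among the compounds with values here, the only measured step that bears on this change is the one from compound 1 to compound 2, and its size is unreadable; no step of known size is available. Compound 3 is therefore expected to show no step beyond the scatter, the expected step being a step that the limit leaves unreadable from compound 1 to compound 3. The value for compound 3 is estimated at 200000 nM, between 100000 nM and 400000 nM.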

Compound 3, half-maximal inhibitory concentration: > 200000 nM
Compound 3 gave a limit, no number (the forecaster's own chance of this, stated with the estimate: 85%); the middle value lies on the limit itself.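

In this assay compound 3 gives > 200000 nM, a limit of the assay and not a number. Within the data shown here, no step among compound 1, compound 2 and compound 3 can be read, as all three values are limits. The compounds shown leave open whether 2-hydroxyphenyl, 4-chlorophenyl and 4-methoxyphenyl differ at all in this read-out.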